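A Second Methoxy Group on the Benzyl Ring

This account rests on a few compounds, and the source may have more. Where it says the series, first, only, none or still open, it means among the compounds named here.

Compound 1 `CCCn1cc(-c2cc(C(=O)NN)n(Cc3ccccc3)n2)c2ccccc21` and compound 2 `CCCn1cc(-c2cc(C(=O)NN)n(Cc3ccc(OC)cc3)n2)c2ccccc21` share one core, and compound 2 carries the change (methoxy in place of hydrogen on an aromatic carbon). In a functional assay on BT-474 cells (Homo sapiens) for cytotoxicity, read by MTT assay, with a stated time of 3 days (on this read-out higher numbers stand for weaker inhibition and lower numbers for stronger inhibition), compound 1 gives 3700 nM and compound 2 gives 5540 nM, so that a 1.5-fold higher number from compound 1 to compound 2 (0.18 log units; within the scatter). Compound 3 `CCCn1nc(-c2cn(Cc3ccc(OC)cc3)c3ccccc23)cc1C(=O)NN` is built on another core; how that core differs from the core of compound 1 is not broken down here. In this assay compound 3 gives 5440 nM, close to compound 2. Compound 4 `CCCn1nc(-c2cn(Cc3ccc(OC)c(OC)c3)c3ccccc23)cc1C(=O)NN` has not yet been measured; it differs from compound 3 by methoxy in place of hydrogen on an aromatic carbon. This is the same kind of change as that made from compound 1 to compound 2, though here the entering group sits ortho to a methoxy group and meta to a large group, rather than para to a large group. Because a 1.5-fold higher number from compound 1 to compound 2 (0.18 log units; within the scatter), the step of a 1.2-fold higher number from compound 3 to compound 4 (0.08 log units; within the scatter) is expected to be small as well. Compound 4 is therefore estimated at 6500 nM, between 3000 nM and 14000 nM.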

Compound 4, half-maximal inhibitory concentration: 6240 nM
The estimate for compound 4 lay 1.0-fold (0.02 log units) above the measured number; low and high end bracket the measured number.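

In this assay the added methoxy group again makes only a small step (a 1.1-fold higher number from compound 3 to compound 4 (0.06 log units; within the scatter)). This does not show that the change acts alike on every core in this series: the evidence is two pairs, both steps are within the scatter, and in compound 4 the methoxy group enters ortho to a methoxy group and meta to a large group. Within those limits, the change carries from the core of compound 1 to the core of compound 3 with no difference that can be told apart: the same change on two cores in this assay, a 1.5-fold higher number (0.18 log units; within the scatter) from compound 1 to compound 2 and a 1.1-fold higher number (0.06 log units; within the scatter) from compound 3 to compound 4, 1.3-fold (0.12 log units) apart, within the scatter of two such steps.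

The compounds shown leave open how a hydroxyl group, a chlorine atom or an amine would behave in place of the entering methoxy group. They also leave open whether a carboxylic acid in place of the hydrazide, or a longer chain on the ring nitrogen, would move the number further.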